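Swapping the five-membered ring on the amide-side methylene

The source may hold more compounds than are shown below. What is called first, only, known or untested is meant among the compounds shown, and "the series" means these compounds.

Measured compounds:
- compound 1 `CCN(Cc1ccsc1)C(=O)COc1ccc(C)cc1`: 88 nM
- compound 2 `CCN(Cc1cccn1C)C(=O)COc1ccc(C)cc1`: 21300 nM

Two compounds share a core and differ only in the small aromatic ring hung from a saturated chain carbon bound to an amide-type nitrogen. In an assay on HEK293 cells for agonist activity at transient receptor potential cation channel subfamily M member 8 (Homo sapiens), read by fluorescence and calcium flux, with a stated time of 15 min (on this read-out lower numbers stand for an effect already at smaller amounts and higher numbers for an effect only at larger amounts of compound), compound 1 gives 88 nM and compound 2 gives 21300 nM. Compound 2 thus stands at the highest number of the two; the one step shown, a 240-fold higher number from compound 1 to compound 2 (2.38 log units; beyond the scatter), is large and well beyond the scatter.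

Compound 3 `CCN(Cc1nccs1)C(=O)COc1ccc(C)cc1` has not yet been measured. Its change from compound 2 is 1,3-thiazol-2-yl in place of 1-methyl-1H-pyrrol-2-yl on a saturated chain carbon bound to an amide-type nitrogen. Within the data shown here, the only step that bears on it is a 240-fold higher number from compound 1 to compound 2 (2.38 log units; beyond the scatter), which shows that exchanging one five-membered ring for another at this place can move the read-out a long way. On these data alone, compound 3 carries a ring with a sulfur atom, as compound 1 does, so the number is expected to fall back toward compound 1 rather than stay near compound 2, although no direct comparison exists and the size remains open. The estimated step is an 11-fold lower number from compound 2 to compound 3 (1.03 log units; beyond the scatter). For compound 3 the expected value in this assay is 2000 nM, with a range from 200 nM to 20000 nM.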

Compound 3, half-maximal effective concentration: 3060 nM
Compound 3: the middle estimate sits 1.5-fold (0.18 log units) below what was measured; the range from low to high includes it.
By their numbers in this assay, from the lowest: compound 1; then compound 3; then compound 2.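

Across three five-membered rings on a saturated chain carbon bound to an amide-type nitrogen, this assay now shows a graded picture rather than a simple good ring and bad ring. Replacing 1-methyl-1H-pyrrol-2-yl with 1,3-thiazol-2-yl gives a 7.0-fold lower number from compound 2 to compound 3 (0.84 log units; beyond the scatter) and so recovers part of the lost ground, yet the comparison with thiophen-3-yl still shows a 35-fold higher number from compound 1 to compound 3 (1.54 log units; beyond the scatter) and leaves compound 3 far from compound 1. A sulfur atom in the ring is therefore not enough on its own to reach the low number of compound 1, and no measurement shown here explains the differences among these rings.

The step from compound 1 to compound 3 changes both the ring atoms and the ring atom that carries the chain, so these two changes cannot be told apart here. Thiophen-2-yl or 1,3-thiazol-4-yl would help separate them, while it remains open where a plain phenyl ring or a ring bearing an amine would fall in this order.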